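A few compounds are considered here, and "the series" means these few. Any claim that something is new, unique, unknown or untested is made for them only; others in the source may bear on it.

Going by the values given here, in a functional assay on DU-145 cells (Homo sapiens) for inhibition, read by trypan blue exclusion, with a stated time of 96 h (a lower number here means a stronger inhibitor of growth, a higher number a weaker inhibitor of growth), compound 1 (`CCOc1ccc(/C=C(/Sc2ccc(C)cc2)C(=O)c2ccc(Br)cc2)cc1OC`) gives 50000 nM and compound 2 (`CCOc1ccc(/C=C(\C(=O)c2ccc(Br)cc2)S(=O)(=O)c2ccc(C)cc2)cc1OC`) gives 1000 nM, the lower of the two numbers so far. Next in the series is compound 3 (`CCOc1ccc(/C=C(\C(=O)c2ccc(Br)cc2)S(=O)(=O)c2ccc(Br)cc2)cc1OC`), which keeps the sulfonyl group of compound 2 but has bromo in place of methyl on an aromatic carbon, para to a large group: bromo in place of methyl on an aromatic carbon. Among the compounds with values here, the only measured step is a 50-fold lower number from compound 1 to compound 2 (1.70 log units; beyond the scatter). It is large, but it is (4-methylphenyl)sulfonyl in place of (4-methylphenyl)sulfanyl and leaves the methyl untouched. Within the data shown here, it therefore bears only indirectly on this change, and no measured pair compares methyl with bromo. With nothing pointing in either direction, no step beyond the scatter is expected in this assay. The estimated step is a 1.3-fold lower number from compound 2 to compound 3 (0.10 log units; within the scatter). For compound 3 the estimated value is 800 nM, with an expected range of 250 nM to 3000 nM.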

Compound 3, concentration for 50% growth inhibition: 1000 nM
The estimate for compound 3 lay 1.3-fold (0.10 log units) below the measured number, within the range that was stated.
By their numbers in this assay, from the lowest: compounds 2 and 3 (each within the scatter of the next); then compound 1.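

In this assay, (4-bromophenyl)sulfonyl in place of (4-methylphenyl)sulfonyl gives no change at the digits printed from compound 2 to compound 3 (within the scatter), so at this aromatic carbon, para to a large group, the two groups cannot be told apart in this assay. The large step seen earlier also survives this change, with a 50-fold lower number from compound 1 to compound 3 (1.70 log units; beyond the scatter) matching the printed size of a 50-fold lower number from compound 1 to compound 2 (1.70 log units; beyond the scatter), so in these compounds it does not depend on keeping the methyl. No supporting measurement bears on why methyl and bromo read alike here.

The compounds shown cover only methyl and bromo at this place, so whether an amine or a carboxylic acid would also leave the number within the scatter remains open. Going by these compounds, whether bromo in place of methyl reads the same on the (4-methylphenyl)sulfanyl compound also remains open.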